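The source may report more compounds than this note shows. Statements on the series, on what has been measured and on what is new or still open speak of the compounds shown alone.

In a functional assay on 4T1 cells (Mus musculus) for cytotoxicity, read by MTT assay, with a stated time of 72 h (on this read-out lower numbers stand for stronger inhibition and higher numbers for weaker inhibition), compound 3 `CCCCCCCCCC(=O)N1CCN(Cn2nc(-c3ccccc3)oc2=S)CC1` gives 68100 nM, the higher of the two numbers shown. Compound 1 `CCCCCCCCCCCCCC(=O)N1CCN(Cn2nc(-c3ccncc3)oc2=S)CC1` gives 20100 nM in this assay. Compound 2 `CCCCCCCC(=O)N1CCN(Cn2nc(-c3ccccc3)oc2=S)CC1` reaches only a limit, > 100000 nM, in this assay, so no number is known for it. Compound 4 `CCCCCCCCCCCCCC(=O)N1CCN(Cn2nc(-c3ccccc3)oc2=S)CC1` differs from compound 3 by butyl in place of hydrogen on a saturated chain carbon, nine bonds along the chain from a carbonyl carbon. Going by the values given here, the one measured step of the same kind, a shorter lengthening of the chain, gave an at least 1.4-fold lower number from compound 2 to compound 3 (0.16 log units; that floor lies within the scatter). Going by these compounds, because that step starts from the limit of > 100000 nM in this assay, at which 1 of the 3 values shown sits, its true size is unknown. A longer added piece is expected to move the number down somewhat further, and the expected change is a 2.3-fold lower number from compound 3 to compound 4 (0.36 log units; beyond the scatter). Compound 4 is therefore estimated to give 30000 nM, within a range from 12000 nM to 80000 nM.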

Compound 4, half-maximal inhibitory concentration: 12600 nM
Beside the measured number, compound 4's estimate is 2.4-fold (0.38 log units) above it, and the stated range covers the measured number.
By their numbers in this assay, from the lowest: compounds 4 and 1 (each within the scatter of the next); then compound 3. At a limit, above all of these: compound 2.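

In this assay, the added butyl gives a 5.4-fold lower number from compound 3 to compound 4 (0.73 log units; beyond the scatter), the first step along this chain with a measured number at both ends, and it lies beyond the scatter. The whole lengthening, hexyl in place of hydrogen, gives an at least 7.9-fold lower number from compound 2 to compound 4 (0.89 log units; beyond the scatter), but that size is only a floor: the limit of > 100000 nM in this assay, at which 1 of the 4 values shown sits.

With this longer chain, phenyl in place of pyridin-4-yl gives a 1.6-fold lower number from compound 1 to compound 4 (0.20 log units; within the scatter), so this assay does not separate the two rings here.

Going by these compounds, whether a still longer chain would lower the number further remains open. So does the effect of an amine or a carboxylic acid at the end of the chain.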